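A few compounds are considered here, and "the series" means these few. Any claim that something is new, unique, unknown or untested is made for them only; others in the source may bear on it.

In a functional assay on GBM3 cells (Homo sapiens) for antiproliferative activity, read by WST assay, with a stated time of 72 h (on this read-out higher numbers stand for weaker inhibition and lower numbers for stronger inhibition), three compounds sharing one core have been measured. Compound 1 (`O=C(Nc1cccc(Cl)c1)Nc1cc2ncncc2cc1OCc1ccccc1Cl`) gives 2800 nM, compound 2 (`O=C(Nc1cccc(Cl)c1)Nc1cc2ncncc2cc1OCc1cccc(Cl)c1`) gives 3500 nM, and compound 3 (`O=C(Nc1ccccc1F)Nc1cc2ncncc2cc1OCc1cccc(Cl)c1`) gives 7500 nM. Compound 2 therefore stands within the scatter of its nearest neighbour and is separated from its furthest by a modest gap.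

Compound 4 (`O=C(Nc1cccc(Cl)c1)Nc1cc2ncncc2cc1OCc1ccccc1`) has not yet been measured. Its difference from compound 2 is hydrogen in place of chloro on an aromatic carbon, which turns (3-chlorobenzyl)oxy into benzyloxy.

Going by the values given here, no measured step removes this chlorine outright, so the evidence is indirect. Among the compounds with values here, the one measured change on the same ring gave a 1.3-fold higher number from compound 1 to compound 2 (0.10 log units; within the scatter), which stays within the scatter. Within the data shown here, the only step beyond the scatter, a 2.1-fold higher number from compound 2 to compound 3 (0.33 log units; beyond the scatter), was made at the other end of the molecule, on the amide-type nitrogen, and it remained modest. A small change is therefore expected in this assay, probably no larger than the scatter and, if anything, towards a slightly higher number. The estimated step is a 1.2-fold higher number from compound 2 to compound 4 (0.08 log units; within the scatter). For compound 4 the expected value is 4200 nM, with an estimated range from 2000 nM to 9000 nM.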

Compound 4, half-maximal inhibitory concentration: 6400 nM
Compound 4: middle estimate off by 1.5-fold (0.18 log units), on the low side; the range from low to high includes it.
By their numbers in this assay, from the lowest: compounds 1, 2, 4 and 3 (each within the scatter of the next, the first and the last beyond it).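

Going by these compounds alone, compound 4 gives the first direct reading of removing the chlorine from the benzyl group: in this assay the change from (3-chlorobenzyl)oxy to benzyloxy gives a 1.8-fold higher number from compound 2 to compound 4 (0.26 log units; within the scatter) and so stays within the scatter. Within the data shown here, the same replacement of chloro by hydrogen, read against the 2-chlorophenyl compound, gives a 2.3-fold higher number from compound 1 to compound 4 (0.36 log units; beyond the scatter) and is the first step at this end of the molecule to pass beyond the scatter, though only modestly. Thus, among these compounds, a clear difference from the unsubstituted benzyl group appears with one chlorine placement but not with the other, while no explanation for this is available from the data given.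

The compounds shown leave open how a fluoro, methoxy or hydroxyl group on this aromatic ring would compare with chloro and hydrogen, and whether a longer chain between the oxygen and the phenyl ring would alter the read-out. They also leave open whether the benzyloxy group would behave in the same way when paired with the 2-fluorophenyl group on the amide-type nitrogen.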